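Chloro on the iodo compound: what to expect

A few compounds are considered here, and "the series" means these few. Any claim that something is new, unique, unknown or untested is made for them only; others in the source may bear on it.

In a functional assay on K562 cells (Homo sapiens) for inhibition, read by trypan blue exclusion, with a stated time of 48 h (on this read-out higher numbers stand for weaker inhibition and lower numbers for stronger inhibition), compound 1 (`NC(=O)c1cc(Br)ccc1NC(=O)/C=C/c1ccccc1`) gives 5000 nM, compound 2 (`NC(=O)c1cc(Br)ccc1NC(=O)/C=C/c1ccccc1Cl`) gives 8100 nM and compound 3 (`NC(=O)c1cc(I)ccc1NC(=O)/C=C/c1ccccc1`) gives 570 nM, the lowest of the three numbers. Iodo in place of bromo accounts for an 8.8-fold lower number from compound 1 to compound 3 (0.94 log units; beyond the scatter), a step beyond the scatter. Compound 4 (`NC(=O)c1cc(I)ccc1NC(=O)/C=C/c1ccccc1Cl`) carries chloro in place of hydrogen on an aromatic carbon, ortho to a large group: chloro in place of hydrogen on an aromatic carbon. The same change has been measured only once, on the bromo compound, as a 1.6-fold higher number from compound 1 to compound 2 (0.21 log units; within the scatter), which lies within the scatter. A similarly small upward shift, or none beyond the scatter, is therefore expected here, although a single step is thin evidence. The expected step is a 1.5-fold higher number from compound 3 to compound 4 (0.17 log units; within the scatter). For compound 4 the estimated value is 850 nM, with an expected range of 320 nM to 2300 nM.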

Compound 4, half-maximal inhibitory concentration: 1200 nM
For compound 4 the middle estimate is 1.4-fold (0.15 log units) below the measured one, and the stated range covers the measured number.
By their numbers in this assay, from the lowest: compound 3; then compound 4; then compounds 1 and 2 (each within the scatter of the next).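

In this assay chloro in place of hydrogen gives a 2.1-fold higher number from compound 3 to compound 4 (0.32 log units; beyond the scatter) and so passes the scatter on the iodo compound, where it stayed within it on the bromo compound. The two steps still agree, and the change reads alike on both cores: the same change on two cores in this assay, a 1.6-fold higher number (0.21 log units; within the scatter) from compound 1 to compound 2 and a 2.1-fold higher number (0.32 log units; beyond the scatter) from compound 3 to compound 4, 1.3-fold (0.11 log units) apart, within the scatter of two such steps. Iodo in place of bromo gives a 6.8-fold lower number from compound 2 to compound 4 (0.83 log units; beyond the scatter) with chloro present, matching its size without chloro: the same change on two cores in this assay, an 8.8-fold lower number (0.94 log units; beyond the scatter) from compound 1 to compound 3 and a 6.8-fold lower number (0.83 log units; beyond the scatter) from compound 2 to compound 4, 1.3-fold (0.11 log units) apart, within the scatter of two such steps.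

Going by these compounds, whether fluoro, methyl or methoxy at this position would track chloro stays open. So does whether an amine would be tolerated there.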